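Notes on the aryl group at the ring nitrogen

The source may hold more compounds than are shown below. What is called first, only, known or untested is meant among the compounds shown, and "the series" means these compounds.

Measured compounds:
compound 1 `O=C(CCCN1CCN(c2ccccc2F)CC1)Nc1ccc(Cl)cc1`: 79.2%
compound 2 `O=C(CCCN1CCN(c2ccc(Cl)cc2)CC1)Nc1ccc(Cl)cc1`: 94.6%

Both numbers come from an assay on HEK293 cells for inhibition of Voltage-dependent T-type calcium channel subunit alpha-1G (Homo sapiens), read by patch clamp, tested at 10 uM; a higher number here means more inhibition at the concentration tested (going by the name of the read-out), a lower number less inhibition. Of the two, compound 1 stands lowest; the nearest, compound 2, lies higher by a number 15.4 percentage points higher from compound 1 to compound 2 (beyond the scatter), a step that is beyond the scatter but modest in size.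

The next compound, compound 3 `COc1cccc(N2CCN(CCCC(=O)Nc3ccc(Cl)cc3)CC2)c1`, is reached from compound 1 by a single change: 3-methoxyphenyl in place of 2-fluorophenyl on an amine nitrogen in a ring.

For the measured compounds named here, only one measured step bears on this change, the one from compound 1 to compound 2, where a different aryl group on the same ring nitrogen gave a number 15.4 percentage points higher from compound 1 to compound 2 (beyond the scatter). Going by the values given here, no measured pair shows the 3-methoxyphenyl group itself, so the direction of the move from compound 1 to compound 3 is not fixed by the data; what the measured step shows is that exchanging the aryl group at this position moves this assay by a modest amount. A change of similar magnitude, in either direction, is expected for compound 3, so the step of a number 4.8 percentage points higher from compound 1 to compound 3 (within the scatter) is expected to be small.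

Compound 3 is therefore expected to give about 84% in this assay, within a range of 65% to 96%.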

Compound 3, a percentage reported as inhibition, at one concentration (the size of the read-out at that concentration, not a potency): 84.1%
The estimate for compound 3 lay 0.1 percentage points below the measured number, and the stated range covers the measured number.
By their numbers in this assay, from the lowest: compounds 1 and 3 (each within the scatter of the next); then compound 2.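

In this assay, the two aryl groups now compared with 2-fluorophenyl behave differently: a number 4.9 percentage points higher from compound 1 to compound 3 (within the scatter), so 3-methoxyphenyl cannot be told apart from 2-fluorophenyl at this ring nitrogen, although the entering group carries 1 hydrogen-bond acceptor and the leaving group has none. The second new step, a number 10.5 percentage points lower from compound 2 to compound 3 (beyond the scatter), shows that the gain seen with 4-chlorophenyl is not shared by 3-methoxyphenyl, leaving compound 2 as the highest of the three, with its steps to both others beyond the scatter. Nothing available here accounts for this difference between the aryl groups.

The three aryl groups differ in both the substituent and its place on the ring, so these compounds do not separate the two, and a plain phenyl, a pyridine ring or a benzyl group at the same nitrogen would test how far the trend extends. As far as these compounds go, each number is also a read-out at a single concentration, so the order of potency among the compounds remains open.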